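This account rests on a few compounds, and the source may have more. Where it says the series, first, only, none or still open, it means among the compounds named here.

Measured in a functional assay on HOS cells (Homo sapiens) for antiproliferative activity, with a stated time of 72 h; a higher number here means a weaker inhibitor, a lower number a stronger inhibitor:
- Compound 1 `OC[C@H]1O[C@@H](n2cnc3c(NCc4ccc(F)cc4)ncnc32)[C@H](O)[C@@H]1O`: 13200 nM
- Compound 2 `OC[C@H]1O[C@@H](n2cnc3c(NCc4ccc(Cl)c(Cl)c4)ncnc32)[C@H](O)[C@@H]1O`: > 166000 nM, a limit
- Compound 3 `OC[C@H]1O[C@@H](n2cnc3c(NCc4cc(O)cc(O)c4)ncnc32)[C@H](O)[C@@H]1O`: > 166000 nM, a limit

Compound 3 has no numerical value and stands only at a limit, > 166000 nM. Compound 4 `OC[C@H]1O[C@@H](n2cnc3c(NCc4cccc(C(F)(F)F)c4)ncnc32)[C@H](O)[C@@H]1O` carries 3-(trifluoromethyl)phenyl in place of 3,5-dihydroxyphenyl on a saturated chain carbon bound to a nitrogen on an aromatic ring.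

Among the measured compounds shown here, two measured steps bear on this change: an at least 12-fold higher number from compound 1 to compound 2 (1.09 log units; beyond the scatter), and an at least 12-fold higher number from compound 1 to compound 3 (1.09 log units; beyond the scatter). Both are large, and only compound 1 gave a number. The remaining comparison is a step that the two limits leave unreadable from compound 2 to compound 3. The new group contains fluorine, as the group of compound 1 does, but compound 2 at > 166000 nM shows that a halogen-bearing ring can still end at the limit. In this assay, a modest move towards a lower number is therefore expected, though compound 4 may well remain at the limit. The expected change is an at least 1.8-fold lower number from compound 3 to compound 4 (0.26 log units; that floor lies within the scatter). The estimated value for compound 4 is 90000 nM, within an expected range from 13000 nM to 200000 nM.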

Compound 4, half-maximal inhibitory concentration: > 166000 nM
Compound 4 gave a limit, no number; the forecaster's own chance of this, stated with the estimate: 55%; middle value at least 1.8-fold (0.26 log units) away from the limit.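

In this assay compound 4 gives only a limit, > 166000 nM. The 3-(trifluoromethyl)phenyl group in place of 4-fluorophenyl gives an at least 12-fold higher number from compound 1 to compound 4 (1.09 log units; beyond the scatter), so fluorine in the entering group does not by itself bring back a number, and compound 1 remains the only compound shown with one. The steps to compound 4 from compound 2 and from compound 3 join two limits and cannot be read, so these three groups cannot be ranked: the limit of > 166000 nM in this assay, at which 3 of the 4 values shown sit.

The compounds shown leave open whether a number belongs to 4-fluorophenyl alone or would also appear with plain phenyl or 4-methoxyphenyl on a saturated chain carbon bound to a nitrogen on an aromatic ring. They also leave open how far past the limit compound 2, compound 3 and compound 4 lie.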